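This account rests on a few compounds, and the source may have more. Where it says the series, first, only, none or still open, it means among the compounds named here.

Compound 1: `COc1cc(/C=C/C(=O)Nc2ccccc2)ccc1OCCCN(C)C` gives 1.55
Compound 2: `CCN(CC)CCCCOc1ccc(/C=C/C(=O)Nc2ccccc2)cc1OC` gives 1.59
Compound 3: `COc1cc(/C=C/C(=O)Nc2ccccc2)ccc1OCCCCCCN1CCCCC1` gives 1.77

These three numbers come from a physicochemical assay for lipophilicity, using the shake flask method, measured as octanol-water partition, at pH 7.4; on this read-out higher numbers stand for higher lipophilicity and lower numbers for lower lipophilicity. Compound 3 holds the highest of the three, but its margin is small: the step of a number 0.18 log units higher from compound 2 to compound 3 (within the scatter) and the step of a number 0.22 log units higher from compound 1 to compound 3 (within the scatter) both lie within the scatter, as does the step of a number 0.04 log units higher from compound 1 to compound 2 (within the scatter), so the three compounds are not separated by this assay.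

Compound 4, `COc1cc(/C=C/C(=O)Nc2ccccc2)ccc1OCCCCCCCCCCN(C)C`, has not yet been measured. Relative to compound 3 the change is 4-(dimethylamino)butyl in place of piperidin-1-yl on a saturated chain carbon, six bonds along the chain from an oxygen on an aromatic ring. Of the measured steps, the one that bears most on this is the step from compound 1 to compound 3, which adds chain and a ring at the same end of the molecule; the step from compound 2 to compound 3 also adds to that end. Both were small. The change to compound 4 adds one more heavy atom and trades the ring for an open chain, so a step of similar modest size, upward if anything, is expected: a number 0.18 log units higher from compound 3 to compound 4 (within the scatter). Compound 4 is therefore estimated at 1.95, with a range from 1.5 to 2.4.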

Compound 4, partition coefficient: 1.8
Compound 4: middle estimate off by 0.15 log units, on the high side, and the stated range covers the measured number.
By their numbers in this assay, from the lowest: compounds 1, 2, 3 and 4 (each within the scatter of the next).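

In this assay, putting 4-(dimethylamino)butyl in place of piperidin-1-yl, on a saturated chain carbon six bonds along the chain from an oxygen on an aromatic ring, gives a number 0.03 log units higher from compound 3 to compound 4 (within the scatter) even though it swaps the ring for an open chain. The two wider changes read no differently, with a number 0.21 log units higher from compound 2 to compound 4 (within the scatter) for 6-(dimethylamino)hexyl in place of diethylamino and a number 0.25 log units higher from compound 1 to compound 4 (within the scatter) for 7-(dimethylamino)heptyl in place of dimethylamino, so none of the changes at this position separates compound 4 from the others. Nothing available accounts for why these steps stay so small.

All four compounds end in an amine without a hydrogen-bond donor, so the compounds shown leave open what a carboxylic acid or a morpholine at the end of this chain would give.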